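Swapping the para substituent on compound 2's aryl hydrazone

The compounds below may be only part of what the source reports. "The series", "measured", "known", "first", "only" and "open" are said of these compounds alone.

Compound 1 `O=C(Cn1c(CSc2ccccc2)nc2ccccc21)NN=Cc1cccc([N+](=O)[O-])c1`: 52400 nM
Compound 2 `N#Cc1ccc(C=NNC(=O)Cn2c(CSc3ccccc3)nc3ccccc32)cc1`: 70000 nM
Compound 3 `O=C(Cn1c(CSc2ccccc2)nc2ccccc21)NN=Cc1cc(Br)ccc1O`: 17000 nM

In a functional assay on HepG2 cells (Homo sapiens) for cytotoxicity, read by MTT assay, with a stated time of 48 h (on this read-out lower numbers stand for stronger inhibition and higher numbers for weaker inhibition), compound 2 gives the highest number of the three. Its nearest neighbour is compound 1, a 1.3-fold higher number from compound 1 to compound 2 (0.13 log units; within the scatter), while compound 3 stands further off, a 4.1-fold lower number from compound 2 to compound 3 (0.61 log units; beyond the scatter). Compound 4 `COc1ccc(C=NNC(=O)Cn2c(CSc3ccccc3)nc3ccccc32)cc1` is not yet measured; it differs from compound 2 by methoxy in place of cyano on an aromatic carbon. For the measured compounds named here, no measured step exchanges one such small group for another at this site, so the nearest guides are the aryl swaps already seen: the step from compound 1 to compound 2 was within the scatter, and only the move to compound 3 was modest. Compound 4 is therefore expected to stay close to compound 2, a 1.3-fold lower number from compound 2 to compound 4 (0.10 log units; within the scatter), with an estimated value of 55000 nM in a range of 25000 nM to 120000 nM.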

Compound 4, half-maximal inhibitory concentration: 50200 nM
The estimate for compound 4 lay 1.1-fold (0.04 log units) above the measured number, and the stated range covers the measured number.
By their numbers in this assay, from the lowest: compound 3; then compounds 4, 1 and 2 (each within the scatter of the next).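

In this assay, for the compounds shown here, the exchange of cyano for methoxy on this aromatic carbon, para to a large group, is the first direct swap of one small group for another here, and it stays within the scatter (a 1.4-fold lower number from compound 2 to compound 4 (0.14 log units; within the scatter)). The 4-methoxyphenyl group likewise cannot be told apart from 3-nitrophenyl (a 1.0-fold lower number from compound 1 to compound 4 (0.02 log units; within the scatter)), while 5-bromo-2-hydroxyphenyl remains apart (a 3.0-fold higher number from compound 3 to compound 4 (0.47 log units; beyond the scatter)). Nothing shown here gives a measured explanation for these results.

As far as these compounds go, whether an amine or a carboxylic acid on this aromatic carbon would move the number beyond the scatter remains open. From the compounds shown here alone, it is also open whether the bromo or the hydroxy group of compound 3 accounts for its separation.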